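The source may report more compounds than this note shows. Statements on the series, on what has been measured and on what is new or still open speak of the compounds shown alone.

In a functional assay on MDA-MB-231 cells (Homo sapiens) for antiproliferative activity, read by MTT assay, with a stated time of 48 h (on this read-out lower numbers stand for stronger inhibition of growth and higher numbers for weaker inhibition of growth), three compounds sharing one core differ only in the chain on the oxygen next to the carbonyl group. Compound 1 `CCOC(=O)N1N=C(c2cccc(OC)c2)CC1c1cc(OC)c(OC)c(OC)c1` gives 9100 nM and compound 2 `CCCOC(=O)N1N=C(c2cccc(OC)c2)CC1c1cc(OC)c(OC)c(OC)c1` gives 12500 nM. These two values stand level, as a 1.4-fold higher number from compound 1 to compound 2 (0.14 log units; within the scatter) shows. Compound 3 `COc1cccc(C2=NN(C(=O)OCc3ccccc3)C(c3cc(OC)c(OC)c(OC)c3)C2)c1` is reported only as a limit, > 10000 nM. That limit leaves an at least 1.0-fold higher number from compound 1 to compound 3 (0.04 log units; that floor lies within the scatter) with little to tell.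

Compound 4 `CCCOC(=O)N1N=C(c2ccc(OC)cc2)CC1c1cc(OC)c(OC)c(OC)c1` keeps the propoxycarbonyl group of compound 2 and changes the other side of the molecule: 4-methoxyphenyl in place of 3-methoxyphenyl on a carbon with a double bond to nitrogen. The two have the same atoms, joined differently. Among the compounds with values here, no measured step touches this place, so the chain steps bear on it only indirectly, and the one readable step, a 1.4-fold higher number from compound 1 to compound 2 (0.14 log units; within the scatter), stays within the scatter. The starting point is therefore compound 2 at 12500 nM, with no direction favoured. The expected change is a 1.0-fold lower number from compound 2 to compound 4 (0.02 log units; within the scatter), which means no step beyond the scatter. For compound 4 the estimated value is 12000 nM, with an expected range of 4500 nM to 30000 nM.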

Compound 4, concentration for 50% growth inhibition: 20400 nM
Estimate against measurement, compound 4: 1.7-fold (0.23 log units) below, within the range that was stated.
By their numbers in this assay, from the lowest: compounds 1, 2 and 4 (each within the scatter of the next, the first and the last beyond it).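

Within the data shown here, compound 1, compound 2 and compound 3 differ only in the chain on the carbonyl side, so this pair is the first to test the aryl group on the carbon with a double bond to nitrogen. In this assay, 4-methoxyphenyl in place of 3-methoxyphenyl gives a 1.6-fold higher number from compound 2 to compound 4 (0.21 log units; within the scatter), so the two isomers stand level and the place of the methoxy group has no readable effect in this pair. Nothing shown here explains the size of this step.

On these data alone, this is a single pair carrying the propoxycarbonyl group, so it remains open whether the same swap would stay level with the ethoxycarbonyl chain of compound 1. Also open, as far as these compounds go, is what a hydroxy group, an amine or a carboxylic acid would do in place of the methoxy group on this ring.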